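The source may report more compounds than this note shows. Statements on the series, on what has been measured and on what is new or still open speak of the compounds shown alone.

Of the compounds shown here, three have been read so far in a physicochemical assay for solubility (on this read-out lower numbers stand for lower solubility and higher numbers for higher solubility), and a fourth awaits measurement. Compound 3 `CNC(=O)c1cc(C(=O)NCCC[C@H]2OC[C@H](N)CO2)cc2c1OC[C@H]2c1ccccc1` gives >= 153 ug/mL as its reading, which is a limit of the assay and not a number. Compound 4 `CNC(=O)c1cc(C(=O)NCCC[C@H]2OC[C@H](N)CO2)cc2c1O[C@H](CF)[C@H]2c1ccccc1` differs from compound 3 by fluoromethyl in place of hydrogen on a saturated ring carbon in one place, with fluoromethyl in place of hydrogen on a saturated ring carbon, next to the ring oxygen and next to the ring atom that bears a phenyl group. For the measured compounds named here, no measured pair isolates this change. The nearest evidence is compound 1 `CNC(=O)c1cc(C(N)=O)cc2c1O[C@H](CF)[C@H]2c1ccccc1` which carries fluoromethyl on the same ring carbon and gives >= 128 ug/mL as its reading, again a limit of the assay. Compound 2 `CNC(=O)c1cc(C(=O)N[C@@H]2C[C@H]2C)cc2c1O[C@H](CF)[C@H]2c1ccccc1` gives 7 ug/mL as a true number. Going by the values given here, the only measured step is an at least 18-fold lower number from compound 1 to compound 2 (1.26 log units; beyond the scatter) and it is large, but it comes with 2-methylcyclopropyl in place of hydrogen on an amide-type nitrogen, so it does not speak to the ring carbon. The expected step is an at least 1.0-fold lower number from compound 3 to compound 4 (0.03 log units; that floor lies within the scatter) and no shift beyond the scatter is expected. For compound 4 the estimate is 140 ug/mL with an expected range from 60 ug/mL to 250 ug/mL in this assay when it is measured.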

Compound 4, solubility: 174 ug/mL
Estimate against measurement, compound 4: 1.2-fold (0.09 log units) below, within the range that was stated.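

With fluoromethyl held on the saturated ring carbon, this assay now gives a step at the amide-type nitrogen that runs between two true numbers: a 25-fold higher number from compound 2 to compound 4 (1.40 log units; beyond the scatter), with a group of 10 heavy atoms holding a six-membered non-aromatic ring with 2 hetero atoms in place of a group of 4 heavy atoms holding a three-membered ring of carbon only. For the compounds shown here, the one earlier step at that nitrogen, an at least 18-fold lower number from compound 1 to compound 2 (1.26 log units; beyond the scatter), starts from a limit, so this is the first step there whose size is fixed at both ends. The steps to compound 4 from compound 1 and from compound 3 cannot be read, because each of those two compounds stands at a limit of the assay and not at a number: the limit of >= 128 ug/mL in this assay, at which 1 of the 4 values shown sits; (the limit of >= 153 ug/mL in this assay, at which 1 of the 4 values shown sits).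

From the compounds shown here alone, whether fluoromethyl on this ring carbon moves the reading at all therefore stays open. Also open, going by these compounds, is how the reading responds to methyl or difluoromethyl on that ring carbon, or to a carboxylic acid in place of the amine on the six-membered ring.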